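From chloro to methoxy on an aromatic carbon

The source may report more compounds than this note shows. Statements on the series, on what has been measured and on what is new or still open speak of the compounds shown alone.

In a functional assay on HL-60 cells (Homo sapiens) for inhibition, read by MTT assay, with a stated time of 48 h (a lower number here means a stronger inhibitor, a higher number a weaker inhibitor), compound 1 `C[C@H]1CCC/C=C/[C@H]2CC[C@H](O)[C@@H](CC(=O)O1)O2` gives 81200 nM and compound 2 `CCO[C@H]1C=C[C@H]2C/C=C\C[C@H](c3ccc(Cl)cc3)OC(=O)C[C@@H]1O2` gives 5700 nM in the same read-out. Compound 2 thus holds the lower of the two numbers, and its gap to compound 1 lies beyond the usual scatter. Compound 3 `CCO[C@H]1C=C[C@H]2C/C=C\C[C@H](c3ccc(OC)cc3)OC(=O)C[C@@H]1O2` carries a single change from compound 2. That change is counted as methoxy in place of chloro on an aromatic carbon and amounts to methoxy in place of chloro on an aromatic carbon, para to a large group. Among the compounds with values here, no measured pair shows a change at this place, so the expectation can start only from compound 2 at 5700 nM and nothing more. In this assay the estimated step is a 1.1-fold higher number from compound 2 to compound 3 (0.06 log units; within the scatter) and it is expected to stay within the scatter, with no direction favoured. For compound 3 the estimated value is 6500 nM with an expected range from 2500 nM to 17000 nM in this read-out.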

Compound 3, half-maximal inhibitory concentration: 69900 nM
Compound 3: the middle estimate sits 11-fold (1.03 log units) below what was measured, outside the stated range (above it).
By their numbers in this assay, from the lowest: compound 2; then compounds 3 and 1 (each within the scatter of the next).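

Within the data shown here, compound 3 gives the first reading at this place, and the step shows that the group on the aromatic ring matters in this assay: replacing 4-chlorophenyl with 4-methoxyphenyl produces a change beyond the scatter (a 12-fold higher number from compound 2 to compound 3 (1.09 log units; beyond the scatter)). Within this pair, chloro holds the lower number, so methoxy cannot stand in for chloro here without a clear loss in this read-out. Nothing at hand bears on why the step is this large.

With only chloro and methoxy shown at this place, the compounds leave open how an amine, a carboxylic acid or a longer chain such as butoxy would read. They also leave open whether the same step would appear on a different core.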